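Removing One Methyl From the Dimethylamino Chain

The source may hold more compounds than are shown below. What is called first, only, known or untested is meant among the compounds shown, and "the series" means these compounds.

Of the compounds shown here, three with a shared core have been tested in a functional assay on CEM-CCRF cells for antagonist activity at C-X-C chemokine receptor type 4 (Homo sapiens), read by calcium flux; on this read-out higher numbers stand for weaker inhibition and lower numbers for stronger inhibition. Compound 1 `NC/C=C\CN(Cc1nc2ccccc2[nH]1)C1CCCc2cccnc21` carries a 3-aminoprop-1-en-1-yl chain and gives 77 nM. Compound 2 `NCC#CCN(Cc1nc2ccccc2[nH]1)C1CCCc2cccnc21`, where that chain is 3-aminoprop-1-yn-1-yl, gives 973 nM, so that a 13-fold higher number from compound 1 to compound 2 (1.10 log units; beyond the scatter). Compound 3 `CN(C)CCCCN(Cc1nc2ccccc2[nH]1)C1CCCc2cccnc21`, with a 3-(dimethylamino)propyl chain, gives 87 nM; here a 1.1-fold higher number from compound 1 to compound 3 (0.05 log units; within the scatter), while an 11-fold lower number from compound 2 to compound 3 (1.05 log units; beyond the scatter). Compound 3 therefore sits with compound 1 at the low, strongly inhibiting end of these three numbers, far from compound 2.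

Compound 4 `CNCCCCN(Cc1nc2ccccc2[nH]1)C1CCCc2cccnc21` differs from compound 3 by hydrogen in place of methyl on an amine nitrogen. For the measured compounds named here, none of the measured steps changes only the count of methyls on this amine nitrogen. Going by the values given here, the two large steps both involve the alkyne chain of compound 2, and the one comparison between a nitrogen with no methyls and one with two, the step from compound 1 to compound 3, also alters the chain and stays within the scatter. On that basis the change to compound 4 is expected to give no step beyond the scatter, a 1.0-fold higher number from compound 3 to compound 4 (0.01 log units; within the scatter). Compound 4 is accordingly estimated at 90 nM in this assay, within a range of 40 nM to 250 nM.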

Compound 4, half-maximal inhibitory concentration: 190 nM
Estimate against measurement, compound 4: 2.1-fold (0.32 log units) below; measured number inside the range.
By their numbers in this assay, from the lowest: compounds 1 and 3 (each within the scatter of the next); then compound 4; then compound 2.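

In this assay, for the compounds shown here, the step to hydrogen in place of methyl on this amine nitrogen is the first change that touches nothing else, and a 2.2-fold higher number from compound 3 to compound 4 (0.34 log units; beyond the scatter) shows that a single methyl here moves the number modestly, beyond the scatter. The earlier step between compound 1 and compound 3 could not show this, since it altered the chain as well as the methyl count, whereas a 2.5-fold higher number from compound 1 to compound 4 (0.39 log units; beyond the scatter) now sets the 3-(methylamino)propyl chain apart from the 3-aminoprop-1-en-1-yl chain, and a 5.1-fold lower number from compound 2 to compound 4 (0.71 log units; beyond the scatter) leaves compound 2, with its 3-aminoprop-1-yn-1-yl chain, as the weakest of the four. Nothing available here explains why losing this methyl raises the number.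

The compounds shown leave open how a 3-aminopropyl chain, with no methyl left on this nitrogen, would read, and so whether the trend from dimethylamino to methylamino continues along the saturated chain. They also leave open whether an ethyl group on this nitrogen, or a longer chain carrying the same dimethylamino group, would keep the number close to that of compound 3.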